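Removing one acetyl from a sesquiterpene ester

The compounds below may be only part of what the source reports. "The series", "measured", "known", "first", "only" and "open" are said of these compounds alone.

Measured so far:
compound 1 `CC1=C[C@H](OC(=O)c2ccc(O)cc2)[C@@H]2[C@](C)(CC[C@@]2(O)C(C)C)CC1=O` gives 26100 nM
compound 2 `COc1ccc(C(=O)O[C@H]2CC(C)=C[C@H](O)[C@@]3(C)[C@@H](OC(C)=O)C[C@@](O)(C(C)C)[C@H]23)cc1` gives 52900 nM
compound 3 `COc1ccc(C(=O)O[C@H]2CC(C)=C[C@@H](OC(C)=O)[C@@]3(C)[C@@H](OC(C)=O)C[C@@](O)(C(C)C)[C@H]23)cc1` gives > 100000 nM

All three were tested in a functional assay on HeLa cells (Homo sapiens) for cytotoxicity, read by MTT assay, with a stated time of 72 h; on this read-out lower numbers stand for stronger inhibition and higher numbers for weaker inhibition. Compound 1 gives 26100 nM and compound 2 gives 52900 nM. Compound 3 sits at the top of the measurable range, and its value is only a limit of the assay, not a number, because of the limit of > 100000 nM in this assay, at which 1 of the 3 values shown sits. Compound 3 is therefore the weakest of the three on the numbers shown, and how far it lies above compound 2 cannot be read from the data.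

Compound 4 `COc1ccc(C(=O)O[C@H]2CC(C)=C[C@@H](O)[C@@]3(C)[C@@H](OC(C)=O)C[C@@](O)(C(C)C)[C@H]23)cc1` has not yet been measured. It differs from compound 3 in one place: hydrogen in place of acetyl on an oxygen on a saturated carbon. Cut one bond further out, the change reads acetoxy to hydroxy.

For the measured compounds named here, no measured pair in this set isolates that change, so no step can be quoted. The expectation is a small step toward stronger inhibition, possibly within the scatter, with a real chance that compound 4 also returns only a limit. Compound 4 is estimated at 80000 nM, within 30000 nM to 250000 nM, which means an expected step of an at least 1.2-fold lower number from compound 3 to compound 4 (0.09 log units; that floor lies within the scatter).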

Compound 4, half-maximal inhibitory concentration: > 100000 nM
Compound 4: no number, only a limit; the forecaster's own chance of this, stated with the estimate: 40%; middle value at least 1.2-fold (0.09 log units) away from the limit.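

In this assay compound 4 gives > 100000 nM, which is a limit of the assay and not a number. Going from acetoxy to hydroxy at this position did not bring a readable value, and the size of the step from compound 3 cannot be read: the limit of > 100000 nM in this assay, at which 2 of the 4 values shown sit. The one readable comparison is an at least 1.8-fold higher number from compound 2 to compound 4 (0.27 log units; that floor lies within the scatter), which hints that the drawn configuration at a saturated ring carbon may matter without showing it beyond the scatter: the fact that compounds 2 and 4 differ only in the configuration as drawn

As far as these compounds go, how far the true values of compound 3 and compound 4 lie past the limit remains open, as does whether compound 2 and compound 4 really differ by more than the scatter. Also open, from the compounds shown here alone, is whether an amine or a carboxylic acid on that saturated ring carbon would give a readable number.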